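Aryl variation at the saturated ring carbon: compound 4

The compounds below may be only part of what the source reports. "The series", "measured", "known", "first", "only" and "open" are said of these compounds alone.

The three measured compounds share one core and differ only in the aryl group on a saturated ring carbon. In a functional assay on Ehrlich cells (Mus musculus) for antiproliferative activity, read by trypan blue exclusion, with a stated time of 2 h, tested at 100 ug/mL (on this read-out higher numbers stand for a stronger effect at the one concentration tested and lower numbers for a weaker effect), compound 1 `Cc1ccc(C2C(C#N)=C(N)N(c3ccc(S(N)(=O)=O)cc3)C3=C2C(=O)CCC3)cc1` gives 100%. Compound 2 `N#CC1=C(N)N(c2ccc(S(N)(=O)=O)cc2)C2=C(C(=O)CCC2)C1c1ccc(Cl)cc1Cl` gives 95% in this assay; the difference between them is a number 5 percentage points lower from compound 1 to compound 2 (within the scatter). Compound 3 `COc1ccc2ccccc2c1C1C(C#N)=C(N)N(c2ccc(S(N)(=O)=O)cc2)C2=C1C(=O)CCC2` gives 80% in this assay and stands lowest of the three numbers, with compound 2 nearest and compound 1 furthest, and both steps leading to it lie beyond the scatter.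

Compound 4 `N#CC1=C(N)N(c2ccc(S(N)(=O)=O)cc2)C2=C(C(=O)CCC2)C1c1cccs1` differs from compound 3 in one place: thiophen-2-yl in place of 2-methoxynaphthalen-1-yl on a saturated ring carbon. The measured steps that bear on this change are the two aryl exchanges at the same saturated ring carbon, a number 20 percentage points lower from compound 1 to compound 3 (beyond the scatter) and a number 15 percentage points lower from compound 2 to compound 3 (beyond the scatter), both modest decreases on arriving at the 2-methoxynaphthalen-1-yl compound. Thiophen-2-yl itself has not been measured in this series, so the expectation rests only on the observation that the two other aryl groups give higher numbers than compound 3. The estimate for compound 4 in this assay is therefore a step upward, a number 10 percentage points higher from compound 3 to compound 4 (within the scatter), back toward the level of compounds 1 and 2. Compound 4 is expected to give 90%, with a range from 75% to 100%.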

Compound 4, a percentage reported as activity, at one concentration (the size of the read-out at that concentration, not a potency): 100%
For compound 4 the middle estimate is 10 percentage points below the measured one; the measured number falls inside the stated range.
By their numbers in this assay, from the lowest: compound 3; then compounds 2, 1 and 4 (each within the scatter of the next).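

In this assay, the saturated ring carbon takes one five-membered aromatic ring with 1 hetero atom as readily as the substituted phenyl groups: no change at the digits printed from compound 1 to compound 4 (within the scatter), and a number 5 percentage points higher from compound 2 to compound 4 (within the scatter), so thiophen-2-yl, 4-methylphenyl and 2,4-dichlorophenyl cannot be told apart on this read-out. Within the data shown here, the one aryl exchange that still registers beyond the scatter involves 2-methoxynaphthalen-1-yl, a number 20 percentage points higher from compound 3 to compound 4 (beyond the scatter), which leaves compound 3 apart from three compounds with different aryl groups rather than two. Nothing at hand accounts for that gap between the aryl groups.

With compound 1 at 100% and compound 4 at 100% in this assay, a single concentration leaves open whether compound 1, compound 2 and compound 4 would separate at lower concentrations. Also open, from the compounds shown here alone, is whether the lower number of compound 3 goes with its second aromatic ring or with its methoxy group, a question that naphthalen-1-yl and 2-methoxyphenyl at this carbon would divide, while furan-2-yl would show whether the sulfur of thiophen-2-yl matters.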